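Chloro in Place of Methyl on a Shared Core

The compounds below may be only part of what the source reports. "The series", "measured", "known", "first", "only" and "open" are said of these compounds alone.

Measured so far:
compound 1 `Fc1ccc2nc(Nc3nc4ccccc4s3)sc2c1`: > 50000 nM; > 50000 nM (2 entries)
compound 2 `Cc1ccc2nc(Nc3nc4ccc(F)cc4s3)sc2c1`: > 50000 nM

In a functional assay on THP-1 cells (Homo sapiens) for cytotoxicity, read by MTT assay, with a stated time of 48 h (on this read-out higher numbers stand for weaker inhibition and lower numbers for stronger inhibition), compound 1 gives only a limit of the assay, > 50000 nM; > 50000 nM (2 entries), not a number. Compound 2 likewise gives only a limit in this assay, > 50000 nM. Compound 2 thus sits at the limit of > 50000 nM in this assay, at which 1 of the 2 values shown sits. Compound 3 `Fc1ccc2nc(Nc3nc4ccc(Cl)cc4s3)sc2c1` has not been measured; it differs from compound 2 by chloro in place of methyl on an aromatic carbon. For the measured compounds named here, with no measured step to lean on, the expected change is a step that the limit leaves unreadable from compound 2 to compound 3, nothing beyond the usual scatter. Compound 3 is expected to give about 70000 nM, somewhere between 20000 nM and 200000 nM, most likely again only a limit.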

Compound 3, half-maximal inhibitory concentration: 41000 nM
Compound 3: the middle estimate sits 1.7-fold (0.23 log units) above what was measured; measured number inside the range.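

In this assay compound 3 gives 41000 nM, a real number rather than a limit, the first on this shared core. Chloro in place of methyl on this aromatic carbon gives an at least 1.2-fold lower number from compound 2 to compound 3 (0.08 log units; that floor lies within the scatter), so the data show no change beyond the usual scatter. The true size of the step stays hidden because compound 2 gives only a limit: the limit of > 50000 nM in this assay, at which 1 of the 3 values shown sits.

On these data alone, whether an amine or a carboxylic acid at this position would give a clearly lower number remains open. So does the effect of a longer chain.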